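A few compounds are considered here, and "the series" means these few. Any claim that something is new, unique, unknown or untested is made for them only; others in the source may bear on it.

Measured compounds:
Compound 1, `CCn1c(=O)/c(=C2\Sc3ccccc3N2C)s/c1=C\c1ccncc1Nc1ccccc1F`: 330 nM in a functional assay on MCF7 cells (Homo sapiens) for inhibition; a higher number here means a weaker inhibitor, a lower number a stronger inhibitor
Compound 2, `CCn1c(=O)/c(=C2\Sc3ccc(C)cc3N2C)s/c1=C\c1ccncc1Nc1ccccc1Cl`: 650 nM
Compound 3, `CCn1c(=O)/c(=C2\Sc3ccc(C)cc3N2C)s/c1=C\c1ccncc1Nc1ccccc1C`: 400 nM

Compound 3 sits among the other two in this assay: its value, that of compound 1 and that of compound 2 all lie within the usual scatter of one another, so none of the three can be separated with confidence.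

Compound 4 is `CCn1c(=O)/c(=C2\Sc3ccc(C)cc3N2C)s/c1=C\c1ccncc1Nc1ccccc1F`. It differs from compound 3 in one place: fluoro in place of methyl on an aromatic carbon. Within the data shown here, one measured step bears on this kind of exchange at the same spot. Going from compound 2 to compound 3 swapped a halogen for a methyl and gave a 1.6-fold lower number from compound 2 to compound 3 (0.21 log units; within the scatter). Compound 1 already carries the fluoro group that enters here, and in this assay compound 1 gives 330 nM, a number that the value of compound 3 overlaps within the scatter. The expectation is therefore a step of about a 1.1-fold lower number from compound 3 to compound 4 (0.05 log units; within the scatter), that is, no movement beyond the scatter. Compound 4 is estimated at 360 nM, with a range from 180 nM to 720 nM.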

Compound 4, half-maximal inhibitory concentration: 100 nM
Beside the measured number, compound 4's estimate is 3.6-fold (0.56 log units) above it; the measured number lies below the stated range.
By their numbers in this assay, from the lowest: compound 4; then compounds 1, 3 and 2 (each within the scatter of the next).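

In this assay this position clearly tells its groups apart: fluoro in place of methyl gives a 4.0-fold lower number from compound 3 to compound 4 (0.60 log units; beyond the scatter) and fluoro in place of chloro gives a 6.5-fold lower number from compound 2 to compound 4 (0.81 log units; beyond the scatter) while chloro and methyl stay within the scatter of each other. So the flat picture from the earlier compounds came from the groups compared, not from a spot where any exchange makes no difference. A step of a 3.3-fold lower number from compound 1 to compound 4 (0.52 log units; beyond the scatter) for methyl in place of hydrogen on the core shows that this second place also counts when the 2-fluorophenyl group is present. No measured evidence here explains why these steps occur. Going by these compounds, what a methoxy group or an amine would do at the fluoro position stays open. So does whether the core methyl gives a similar step alongside chloro or methyl.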